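Compound 3: nitro in place of methoxy

A few compounds are considered here, and "the series" means these few. Any claim that something is new, unique, unknown or untested is made for them only; others in the source may bear on it.

In a functional assay on HCT-116 cells (Homo sapiens) for inhibition, read by CCK-8 assay, with a stated time of 48 h (a higher number here means a weaker inhibitor, a lower number a stronger inhibitor), compound 1 (`COc1ccc(CN(C(=O)CN2CCN(C(C)=O)CC2)c2cc(OC)c(OC)c(OC)c2)cc1`) gives > 20000 nM, which is a limit of the assay and not a number. Compound 2 (`COc1ccc(CN(C(=O)CSC(=S)N2CCN(C(=O)OC(C)(C)C)CC2)c2cc(OC)c(OC)c(OC)c2)cc1OC`) gives > 20000 nM, also a limit and not a number. Compound 2 therefore has no exact position on the scale, and the only reference is the limit of > 20000 nM in this assay, at which 2 of the 2 values shown sit.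

Compound 3 (`COc1ccc(CN(C(=O)CSC(=S)N2CCN(C(=O)OC(C)(C)C)CC2)c2cc(OC)c(OC)c(OC)c2)cc1[N+](=O)[O-]`) keeps the frame of compound 2 but has nitro in place of methoxy on an aromatic carbon, ortho to a methoxy group and meta to a large group: nitro in place of methoxy on an aromatic carbon. The 3,4-dimethoxybenzyl becomes 4-methoxy-3-nitrobenzyl.

Going by the values given here, no measured step guides this change, so only a modest shift toward stronger inhibition is expected, and a result at the limit remains likely. The expected step of an at least 1.3-fold lower number from compound 2 to compound 3 (0.12 log units; that floor lies within the scatter) is small. For compound 3 the estimated value is 15000 nM, with an expected range of 3000 nM to 40000 nM.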

Compound 3, half-maximal inhibitory concentration: 980 nM
The estimate for compound 3 lay 15-fold (1.18 log units) above the measured number, outside the stated range (below it).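

In this assay, replacing 3,4-dimethoxybenzyl with 4-methoxy-3-nitrobenzyl gives an at least 20-fold lower number from compound 2 to compound 3 (1.30 log units; beyond the scatter), and compound 3 is the first compound shown with a value that is a number and not a limit. Compound 2 gives > 20000 nM, which is a limit of the assay and not a number. This aromatic carbon, ortho to a methoxy group and meta to a large group, is therefore a place where one replacement is enough to bring the series off the limit, which otherwise holds for most of the values: the limit of > 20000 nM in this assay, at which 2 of the 3 values shown sit.

A single pair cannot separate the entry of nitro from the loss of methoxy, and a nitrile, an amine or a plain hydrogen on this carbon would tell these readings apart. As far as these compounds go, whether nitro at this place has a similar effect in the frame of compound 1 also remains open.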